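A Five-Membered Ring Swap on a Shared Core

A few compounds are considered here, and "the series" means these few. Any claim that something is new, unique, unknown or untested is made for them only; others in the source may bear on it.

Compound 1 `O=C1OCCN1c1cc(C(F)(F)F)ccc1[C@H]1CCOc2cc(S(=O)(=O)Nc3nccs3)ccc21`: 2.1
Compound 2 `Cc1ccc(-c2cc(C(F)(F)F)ccc2[C@H]2CCOc3cc(S(=O)(=O)Nc4ncc(F)cn4)ccc32)cn1`: 2.5

In a physicochemical assay for lipophilicity (on this read-out lower numbers stand for lower lipophilicity and higher numbers for higher lipophilicity), compound 1 gives 2.1, the lowest of the two numbers. Compound 2 gives 2.5 in this assay, a value higher than that of compound 1 by more than the usual scatter. Compound 3 `Cc1nc(-c2cc(C(F)(F)F)ccc2[C@H]2CCOc3cc(S(=O)(=O)Nc4nccs4)ccc32)co1` differs from compound 1 in one place: 2-methyl-1,3-oxazol-4-yl in place of 2-oxo-1,3-oxazolidin-3-yl on an aromatic carbon. Among the measured compounds shown here, no measured pair shows this change, so the expectation rests on the nature of the groups alone: a moderate rise in this assay, beyond the scatter, is expected, amounting to a number 0.80 log units higher from compound 1 to compound 3 (beyond the scatter). For compound 3 the estimate in this assay is 2.9, expected to fall between 2.4 and 3.4.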

Compound 3, distribution coefficient: 2.9
The estimate for compound 3 equals the measured number at the digits printed, within the range that was stated.
By their numbers in this assay, from the lowest: compound 1; then compound 2; then compound 3.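

In this assay, this position on an aromatic carbon, meta to a trifluoromethyl group, gave the first one-place step: 2-methyl-1,3-oxazol-4-yl in place of 2-oxo-1,3-oxazolidin-3-yl produced a number 0.80 log units higher from compound 1 to compound 3 (beyond the scatter). The two groups have the same counts of heavy atoms, hydrogen-bond donors and hydrogen-bond acceptors, while the ring changes from non-aromatic to aromatic. No available measurement accounts for the size of this step. Still open, as far as these compounds go, is how an amine or a carboxylic acid at this position would read in this assay, and whether this exchange gives a similar step on another core.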